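A Ring Gives Way to a Chain

The source may hold more compounds than are shown below. What is called first, only, known or untested is meant among the compounds shown, and "the series" means these compounds.

In a functional assay on HCT-116 cells (Homo sapiens) for cytotoxicity, read by MTT assay, with a stated time of 72 h (a higher number here means a weaker inhibitor, a lower number a stronger inhibitor), compound 1 `CS(=O)(=O)Oc1c(C(=O)NCc2ccc(F)cc2)nc(Br)c2cccnc12` reads > 20000 nM, which is a limit of the assay. Compound 2 `Nc1ccc(Nc2c(C(=O)NCc3ccc(F)cc3)nc(Br)c3cccnc23)cc1` gives 10000 nM and compound 3 `N[C@H]1CC[C@H](Nc2c(C(=O)NCc3ccc(F)cc3)nc(Br)c3cccnc23)CC1` gives 7000 nM, two values within the scatter of each other. Compound 4 `CNCCCNc1c(C(=O)NCc2ccc(F)cc2)nc(Br)c2cccnc12` differs from compound 3 by 3-(methylamino)propyl in place of 4-aminocyclohexyl on a nitrogen on an aromatic ring, with 3-(methylamino)propyl in place of 4-aminocyclohexyl on a nitrogen on an aromatic ring. The closest measured change, a 1.4-fold lower number from compound 2 to compound 3 (0.15 log units; within the scatter), exchanged the group on that same nitrogen and stayed within the scatter, whereas an at least 2.8-fold lower number from compound 1 to compound 3 (0.45 log units; beyond the scatter) replaced (methylsulfonyl)oxy, a different kind of change. On that basis, an estimated 1.2-fold lower number from compound 3 to compound 4 (0.07 log units; within the scatter) is expected, which means no step beyond the scatter. Compound 4 is expected at about 6000 nM, within an estimated range of 2500 nM to 15000 nM.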

Compound 4, half-maximal inhibitory concentration: 9000 nM
Compound 4: middle estimate off by 1.5-fold (0.18 log units), on the low side; the measured number falls inside the stated range.
By their numbers in this assay, from the lowest: compounds 3, 4 and 2 (each within the scatter of the next). At a limit, above all of these: compound 1.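

In this assay, a chain with no ring holds the same level on this nitrogen, with a 1.3-fold higher number from compound 3 to compound 4 (0.11 log units; within the scatter) and a 1.1-fold lower number from compound 2 to compound 4 (0.05 log units; within the scatter), so neither the six-membered non-aromatic ring nor the two defined stereocentres of compound 3 is needed to keep it there. Replacing (methylsulfonyl)oxy with (3-(methylamino)propyl)amino gives an at least 2.2-fold lower number from compound 1 to compound 4 (0.34 log units; beyond the scatter). Compound 1 stands at a limit of the assay: the limit of > 20000 nM in this assay, at which 1 of the 4 values shown sits.

As far as these compounds go, whether the amine at the chain end matters remains open, since every amine-bearing compound here carries one. A chain ending in a hydroxyl or a carboxylic acid could settle that.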